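The compounds below may be only part of what the source reports. "The series", "measured", "known", "first", "only" and "open" are said of these compounds alone.

Compound 1 `CC(C)Cc1ccc2c(NCCCNCc3ccco3)ccnc2c1` is the point of departure. In an ADME assay on HepG2 cells (Homo sapiens) for cytotoxicity, read by luminescence, CellTiter-Glo and ATP content, with a stated time of 72 h (a lower number here means that less compound is needed, a higher number that more compound is needed for the effect), compound 1 gives 16000 nM, and compound 3 `Fc1ccc(Oc2ccc3c(NCCCNCc4ccco4)ccnc3c2)cc1` gives 16000 nM, so the two stand level, together the highest of the three numbers; the step of no change at the digits printed from compound 1 to compound 3 (within the scatter) confirms this. Compound 2 `c1ccc(-c2ccc3c(NCCCNCc4ccco4)ccnc3c2)cc1` gives 5920 nM, a modest distance away: the step of a 2.7-fold lower number from compound 1 to compound 2 (0.43 log units; beyond the scatter) and the reverse-direction step a 2.7-fold higher number from compound 2 to compound 3 (0.43 log units; beyond the scatter) are of the same modest size.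

Compound 4 `COc1ccc(F)cc1CNCCCNc1ccnc2cc(CC(C)C)ccc12` has not yet been measured. It differs from compound 1 by 5-fluoro-2-methoxyphenyl in place of furan-2-yl on a saturated chain carbon bound to an amine nitrogen. Every measured step in this set changes the group on an aromatic carbon of the shared core and leaves the furan-2-yl untouched, so none of them speaks directly to this change. With only the modest spread seen across compounds 1, 2 and 3 as a guide, a step of no change at the digits printed from compound 1 to compound 4 (within the scatter) is expected, that is, nothing beyond the scatter. For compound 4 the estimate in this assay is 16000 nM, within a range of 6000 nM to 40000 nM.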

Compound 4, half-maximal effective concentration: 2900 nM
Estimate against measurement, compound 4: 5.5-fold (0.74 log units) above; measured number below the stated range.
By their numbers in this assay, from the lowest: compound 4; then compound 2; then compounds 1 and 3 (each within the scatter of the next).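

In this assay, the group on a saturated chain carbon bound to an amine nitrogen proves able to shift the number: 5-fluoro-2-methoxyphenyl in place of furan-2-yl gives a 5.5-fold lower number from compound 1 to compound 4 (0.74 log units; beyond the scatter). Going by these compounds alone, the earlier steps changed only the group on an aromatic carbon of the shared core, so this is the first sign that a change away from that carbon also matters in this assay, here with the hydrogen-bond acceptor count of the two groups the same. Nothing available explains the step.

The compounds shown do not separate the share of the ring exchange from that of the fluorine or the methoxy group, which a plain phenyl or a pyridine ring at this place would address. On these data alone, whether the same exchange holds with the phenyl or 4-fluorophenoxy group on the core also remains open.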